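The source may hold more compounds than are shown below. What is called first, only, known or untested is meant among the compounds shown, and "the series" means these compounds.

In an in vitro ADME assay on microsomes from liver (Canis lupus familiaris) for metabolic stability (on this read-out lower numbers stand for slow clearance and higher numbers for fast clearance), two compounds sharing one core have been measured so far. Compound 1 `CCC(CC)[C@@H]1C(=O)N[C@H](C2Cc3ccccc3C2)C(=O)N1[C@@H](C(=O)N1CCOCC1)c1ccc(C)nc1`, with a pentan-3-yl group, gives 5 mL.min-1.g-1, and compound 2 `CC[C@@H](C)[C@@H]1C(=O)N[C@H](C2Cc3ccccc3C2)C(=O)N1[C@@H](C(=O)N1CCOCC1)c1ccc(C)nc1`, with sec-butyl in its place, gives 2 mL.min-1.g-1, the lower of the two numbers.

Compound 3 `CC[C@H](C)[C@@H]1C(=O)N[C@H](C2Cc3ccccc3C2)C(=O)N1[C@@H](C(=O)N1CCOCC1)c1ccc(C)nc1` differs from compound 2 as follows: the two compounds have the same atoms and bonds and differ only in configuration as drawn: 1 of 4 stereo elements differ; a stereocentre at a saturated chain carbon is drawn R in compound 2 and S in compound 3. The two have the same atoms and bonds, and a stereocentre at a saturated chain carbon is drawn R in compound 2 and S in compound 3.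

For the measured compounds named here, no measured pair shows a swap of configuration like this one, so the evidence is thin. Going by the values given here, the only guide is a 2.5-fold lower number from compound 1 to compound 2 (0.40 log units; beyond the scatter), a modest step beyond the scatter, and that step exchanged one group for another. A change that leaves every atom in place is expected to stay within the scatter, and the expected step is a 1.5-fold higher number from compound 2 to compound 3 (0.18 log units; within the scatter). Going by these compounds, the direction remains open, with only a slight upward lean in the estimate. For compound 3 the estimated value is 3 mL.min-1.g-1, with an expected range from 1.3 mL.min-1.g-1 to 7 mL.min-1.g-1.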

Compound 3, intrinsic clearance in microsomes: 2 mL.min-1.g-1
Compound 3: middle estimate off by 1.5-fold (0.18 log units), on the high side; low and high end bracket the measured number.
By their numbers in this assay, from the lowest: compounds 2 and 3 (each within the scatter of the next); then compound 1.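

In this assay, swapping the configuration at this saturated chain carbon from R to S gives no change at the digits printed from compound 2 to compound 3 (within the scatter), so at this position the read-out does not separate the two drawn forms. The drop seen on going from the pentan-3-yl group to the sec-butyl group also appears with the second form: the new comparison gives a 2.5-fold lower number from compound 1 to compound 3 (0.40 log units; beyond the scatter), the same size as the earlier 2.5-fold lower number from compound 1 to compound 2 (0.40 log units; beyond the scatter), so the lower number goes with sec-butyl in either configuration. This makes the comparison between compound 2 and compound 3 a clean test of configuration alone, with no other part of the structure involved: the fact that compounds 2 and 3 differ only in the configuration as drawn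

Going by these compounds, it remains open whether an isopropyl group, or a longer chain such as n-hexyl, at this position would stay as low as the sec-butyl compounds or come closer to compound 1, and what lies behind the difference between these groups. On these data alone, the other stereocentres also stay untested, so the lack of a configuration effect here cannot be carried over to them, nor to any read-out other than this assay.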